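The compounds below may be only part of what the source reports. "The series", "measured", "known", "first", "only" and "open" are said of these compounds alone.

Measured compounds:
compound 1, `c1ccc(-c2nn(-c3ccccc3)cc2-c2nc3ccccc3[nH]2)cc1`, 2710 nM in a functional assay on A549 cells (Homo sapiens) for antiproliferative activity, read by MTT assay, with a stated time of 48 h; on this read-out higher numbers stand for weaker inhibition and lower numbers for stronger inhibition
compound 2, `Clc1ccc2[nH]c(-c3cn(-c4ccccc4)nc3-c3ccccc3)nc2c1`, 2370 nM in this assay
compound 3, `COc1ccc(-c2nn(-c3ccccc3)cc2-c2nc3cc(Cl)ccc3[nH]2)cc1`, 3130 nM in this assay

Compound 4, `COc1ccc(-c2nn(-c3ccccc3)cc2-c2nc3cc(Cl)c(Cl)cc3[nH]2)cc1`, has not been measured. Compound 2 differs from compound 1 by chloro in place of hydrogen on an aromatic carbon and that gave a 1.1-fold lower number from compound 1 to compound 2 (0.06 log units; within the scatter). The difference between the core of compound 1 and the core of compound 3 is not broken down here. Compound 4 differs from compound 3 by chloro in place of hydrogen on an aromatic carbon. Among the measured compounds shown here, this is the same kind of change as the one from compound 1 to compound 2, but here the entering chloro sits ortho to a chloro group already present. For the measured compounds named here, with only one earlier example, the step from compound 3 to compound 4 is expected to be similar in size, a 1.2-fold lower number from compound 3 to compound 4 (0.08 log units; within the scatter), because a 1.1-fold lower number from compound 1 to compound 2 (0.06 log units; within the scatter). Compound 4 is therefore expected to give about 2600 nM, likely between 1200 nM and 5600 nM.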

Compound 4, half-maximal inhibitory concentration: 7330 nM
Beside the measured number, compound 4's estimate is 2.8-fold (0.45 log units) below it; the whole stated range lies below it.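

In this assay, adding a chloro ortho to a chloro group already present gives a 2.3-fold higher number from compound 3 to compound 4 (0.37 log units; beyond the scatter). Set beside the earlier case, the same swap of hydrogen for chloro does not carry over unchanged from one core to the other: the same change on two cores in this assay, a 1.1-fold lower number (0.06 log units; within the scatter) from compound 1 to compound 2 and a 2.3-fold higher number (0.37 log units; beyond the scatter) from compound 3 to compound 4, 2.7-fold (0.43 log units) apart, beyond the scatter of two such steps. This rests on just two pairs that differ both in the core and in whether a chloro group is already present, so it does not show which of these matters, or how the change would behave on any other core.

The compounds shown leave open whether the second chloro would have the same effect without the methoxy group. Also open, on these data alone, is how a fluoro, a methyl or an amine would compare with chloro at this place.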